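A few compounds are considered here, and "the series" means these few. Any claim that something is new, unique, unknown or untested is made for them only; others in the source may bear on it.

Working notes on the series. Compound 1, `N=c1c2c(-c3ccccc3)c(-c3ccccc3)n(Cc3ccccc3)c2ncn1C1CCN(Cc2ccccc2)CC1`, has no reported result in an ADME assay for permeability, using PAMPA, with a stated time of 30 min, at pH 7.4; a higher number here means that the compound crosses the layer faster, a lower number that the compound crosses the layer more slowly: compound 1 gives "nd" (no result reported). Compound 3, `N=c1c2c(-c3ccccc3)c(-c3ccccc3)n(Cc3ccccc3)c2ncn1CCCN1CCN(c2ccccc2)CC1`, is reported only as a limit of the assay; in this assay compound 3 gives > 1000 10^-6 cm/s. Compound 2, `COc1ccc(Cn2c(-c3ccccc3)c(-c3ccccc3)c3c(=N)n(CCCO)cnc32)cc1`, likewise stands at a limit of the assay rather than at a number; in this assay compound 2 gives > 1000 10^-6 cm/s. For the measured compounds named here, no pair of measured compounds differs in a single place, so no measured step exists in the set; the one fixed point is the limit of > 1000 10^-6 cm/s in this assay, at which 2 of the 3 values shown sit.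

Compound 4 is `COc1ccc(Cn2c(-c3ccccc3)c(-c3ccccc3)c3c(=N)n(CC4CCOCC4)cnc32)cc1`. It differs from compound 2 as follows: oxan-4-yl in place of 2-hydroxyethyl on a saturated chain carbon bound to an aromatic nitrogen. With compound 2 already at the limit, the step from compound 2 to compound 4 is expected to show no change beyond the scatter in this assay, and it is expected that a step that the limit leaves unreadable from compound 2 to compound 4 will again be reported only as a limit. For compound 4 an apparent permeability of 1200 10^-6 cm/s is estimated, in the range 600 10^-6 cm/s to 2500 10^-6 cm/s.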

Compound 4, apparent permeability: 1270 10^-6 cm/s
Compound 4: the middle estimate sits 1.1-fold (0.02 log units) below what was measured, within the range that was stated.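

No step from compound 2 to compound 4 can be read, because compound 2 gives only a limit and not a number: the limit of > 1000 10^-6 cm/s in this assay, at which 2 of the 4 values shown sit.

The compounds shown leave open whether oxan-4-yl in place of 2-hydroxyethyl changes the read-out in this assay at all, and in which direction.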